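Working notes: compound 4 awaits its cytotoxicity number

The source may hold more compounds than are shown below. What is called first, only, known or untested is meant among the compounds shown, and "the series" means these compounds.

Measured so far:
- compound 1 `CCCCNc1ccnc2cc(F)ccc12`: in a functional assay on MDA-MB-468 cells (Homo sapiens) for cytotoxicity, read by sulforhodamine B assay, with a stated time of 48 h, in the presence of a further agent that is not named here (on this read-out higher numbers stand for weaker inhibition of growth and lower numbers for stronger inhibition of growth), compound 1 gives 2090 nM
- compound 2 `CN(C)CCNc1ccnc2cc(Cl)ccc12`: in this assay compound 2 gives 6500 nM
- compound 3 `CN(C)CCNc1ccnc2cc(F)ccc12`: in this assay compound 3 gives 4950 nM

Compound 3 holds the second highest of the three numbers in this assay; its step of a 1.3-fold lower number from compound 2 to compound 3 (0.12 log units; within the scatter) is within the scatter, while a 2.4-fold higher number from compound 1 to compound 3 (0.37 log units; beyond the scatter) is beyond it. Compound 4 `COc1ccc2c(NCCN(C)C)ccnc2c1` differs from compound 3 by methoxy in place of fluoro on an aromatic carbon. Going by the values given here, no measured step swaps a halogen for methoxy; the only change at that place, a 1.3-fold lower number from compound 2 to compound 3 (0.12 log units; within the scatter), was within the scatter, and the chain change a 2.4-fold higher number from compound 1 to compound 3 (0.37 log units; beyond the scatter) concerns another site. No step beyond the scatter is therefore expected in this assay, giving an estimated 1.0-fold higher number from compound 3 to compound 4 (0.00 log units; within the scatter). Compound 4 is estimated at 5000 nM, between 2000 nM and 13000 nM.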

Compound 4, concentration for 50% growth inhibition: 5910 nM
Compound 4: middle estimate off by 1.2-fold (0.07 log units), on the low side; the measured number falls inside the stated range.
By their numbers in this assay, from the lowest: compound 1; then compounds 3, 4 and 2 (each within the scatter of the next).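

In this assay, going by these compounds alone, methoxy is the first group on this aromatic carbon that is not a halogen, yet it stays within the scatter of both halogens: a 1.2-fold higher number from compound 3 to compound 4 (0.08 log units; within the scatter) for methoxy in place of fluoro, and a 1.1-fold lower number from compound 2 to compound 4 (0.04 log units; within the scatter) for methoxy in place of chloro. With the dimethylamino chain held constant, fluoro, chloro and methoxy cannot be told apart at this place, although methoxy brings a hydrogen-bond acceptor. No supporting data bear on this result.

Still open, from the compounds shown here alone, is whether an amine or a carboxylic acid on this carbon would give a step beyond the scatter. Also open, going by these compounds, is whether methoxy matches fluoro on the chain of compound 1.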